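Chalcone Series: Swapping Chloro for Trifluoromethyl

The compounds below may be only part of what the source reports. "The series", "measured", "known", "first", "only" and "open" are said of these compounds alone.

Measured so far in a functional assay on HeLa cells (Homo sapiens) for inhibition, read by MTT assay, with a stated time of 72 h; on this read-out lower numbers stand for stronger inhibition and higher numbers for weaker inhibition:
- compound 1, `COc1cc(O)cc(O)c1C(=O)/C=C/c1ccc(O)cc1`, gives 48100 nM
- compound 2, `COc1cc(O)cc(O)c1C(=O)/C=C/c1ccc(C)cc1`, gives a limit of the assay, > 50000 nM
- compound 3, `COc1cc(O)cc(O)c1C(=O)/C=C/c1ccc(Cl)cc1`, gives 17000 nM

Three compounds share one core and differ only in the group on the far aromatic ring. Compound 3 stands lowest of the two numbers given, with compound 1 nearest; the value for compound 2 is a limit and not a number, as the limit of the limit of > 50000 nM in this assay, at which 1 of the 3 values shown sits, shows.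

Compound 4, `COc1cc(O)cc(O)c1C(=O)/C=C/c1ccc(C(F)(F)F)cc1`, has not yet been measured. trifluoromethyl in place of chloro on an aromatic carbon

The steps already seen bear on this change. a 2.8-fold lower number from compound 1 to compound 3 (0.45 log units; beyond the scatter) and an at least 2.9-fold lower number from compound 2 to compound 3 (0.46 log units; beyond the scatter) both show that a chloro group on this ring gives a modestly lower number than hydroxy or methyl. Trifluoromethyl is a further change of the same group, but no measured step tells how it compares with chloro, so the expected step is small. The step is estimated at a 1.1-fold lower number from compound 3 to compound 4 (0.05 log units; within the scatter), within the usual scatter. Compound 4 is therefore expected to give about 15000 nM, plausibly between 6000 nM and 40000 nM.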

Compound 4, half-maximal inhibitory concentration: 9500 nM
For compound 4 the middle estimate is 1.6-fold (0.20 log units) above the measured one; low and high end bracket the measured number.
By their numbers in this assay, from the lowest: compounds 4 and 3 (each within the scatter of the next); then compound 1. At a limit, above all of these: compound 2.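

In this assay, trifluoromethyl in place of chloro gives a 1.8-fold lower number from compound 3 to compound 4 (0.25 log units; within the scatter), so these two groups cannot be told apart at this position. The new result shows that chloro is not alone here: a second group also stands clearly apart from hydroxy, with a 5.1-fold lower number from compound 1 to compound 4 (0.70 log units; beyond the scatter), and from methyl, with an at least 5.2-fold lower number from compound 2 to compound 4 (0.72 log units; beyond the scatter). That last step is only a floor, as the value of compound 2 is a limit and not a number: the limit of > 50000 nM in this assay, at which 1 of the 4 values shown sits.

On these data alone, whether an amine, a carboxylic acid or a longer chain at this position would give a number like those of compound 3 and compound 4 remains open. Also open, as far as these compounds go, is how chloro and trifluoromethyl would compare on another carbon of this ring.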